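Lengthening the Amide Chain from Propyl to Butyl

The source may report more compounds than this note shows. Statements on the series, on what has been measured and on what is new or still open speak of the compounds shown alone.

Compound 1 `CCC1C(=O)N(C)c2cnc(-n3ccc4cc(C(=O)NC(C)C)ccc43)nc2N1c1ccn(C)n1` carries an isopropyl group on its amide nitrogen and in an assay for inhibition of serine/threonine-protein kinase PLK2 (Homo sapiens), read by FRET and Z'-LYTE, with a stated time of 1 h (a lower number here means a stronger inhibitor, a higher number a weaker inhibitor), compound 1 gives 125 nM. Compound 2 `CCCNC(=O)c1ccc2c(ccn2-c2ncc3c(n2)N(c2ccn(C)n2)C(CC)C(=O)N3C)c1` carries a propyl group instead, and in this assay compound 2 gives 207 nM, a step of a 1.7-fold higher number from compound 1 to compound 2 (0.22 log units; within the scatter), so the two compounds stand alongside each other. Compound 3 `CCCCNC(=O)c1ccc2c(ccn2-c2ncc3c(n2)N(c2ccn(C)n2)C(CC)C(=O)N3C)c1` differs from compound 2 by methyl in place of hydrogen on a saturated chain carbon, three bonds along the chain from an amide-type nitrogen. Among the compounds with values here, the only step that bears on this, from compound 1 to compound 2, was small, so a similar step is expected, a 1.4-fold higher number from compound 2 to compound 3 (0.13 log units; within the scatter). In this assay compound 3 is expected to give about 280 nM, estimated between 120 nM and 650 nM.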

Compound 3, half-maximal inhibitory concentration: 159 nM
Beside the measured number, compound 3's estimate is 1.8-fold (0.25 log units) above it; low and high end bracket the measured number.
By their numbers in this assay, from the lowest: compounds 1, 3 and 2 (each within the scatter of the next).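

In this assay propyl to butyl gives a 1.3-fold lower number from compound 2 to compound 3 (0.11 log units; within the scatter) and butyl in place of isopropyl gives a 1.3-fold higher number from compound 1 to compound 3 (0.10 log units; within the scatter) on the same amide nitrogen. Isopropyl, propyl and butyl at this position therefore cannot be told apart in these compounds, so extending the chain by one methyl leaves the reading within the scatter. Nothing measured here offers an explanation for this flat result. From the compounds shown here alone, it remains open whether a longer chain such as hexyl would read the same. The same holds for a chain ending in an amine or a carboxylic acid.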